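Urea Tail Variation on a Quinazoline-Linked Series

This account rests on a few compounds, and the source may have more. Where it says the series, first, only, none or still open, it means among the compounds named here.

Compounds measured so far:
compound 1 `COc1cc2ncnc(NCc3cccc(NC(=O)Nc4ccccc4)c3)c2cc1OC` with 10000 nM in a functional assay on MGC-803 cells (Homo sapiens) for antiproliferative activity, read by MTT assay; a lower number here means a stronger inhibitor, a higher number a weaker inhibitor
compound 2 `COc1cc2ncnc(NCc3cccc(NC(=O)Nc4ccccc4F)c3)c2cc1OC` with 10300 nM in this assay

Compound 2 gives the highest of the two numbers in this assay, but its nearest neighbour, compound 1, lies within the scatter of it: the step of a 1.0-fold higher number from compound 1 to compound 2 (0.01 log units; within the scatter) is too small to count as a change. Compound 3 `COc1cc2ncnc(NCc3cccc(NC(=O)Nc4ccc(Cl)cc4)c3)c2cc1OC` is not yet measured. It differs from compound 2 by 4-chlorophenyl in place of 2-fluorophenyl on an amide-type nitrogen. Among the measured compounds shown here, no measured step bears directly on this exchange; the only step available, fluoro in place of hydrogen on the aromatic ring of the urea, left the number in this assay unchanged. On that basis no movement beyond the scatter is expected for compound 3, and the step of a 1.0-fold lower number from compound 2 to compound 3 (0.01 log units; within the scatter) is estimated to stay flat. Compound 3 is therefore expected to give about 10000 nM in this assay, within a range of 4000 nM to 25000 nM.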

Compound 3, half-maximal inhibitory concentration: 44200 nM
The estimate for compound 3 lay 4.4-fold (0.65 log units) below the measured number; the whole stated range lies below it.
By their numbers in this assay, from the lowest: compounds 1 and 2 (each within the scatter of the next); then compound 3.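

In this assay, the aryl tail of the urea turned out not to be indifferent to substitution: 4-chlorophenyl in place of 2-fluorophenyl on the amide-type nitrogen gave a 4.3-fold higher number from compound 2 to compound 3 (0.63 log units; beyond the scatter), and adding the chloro group to the unsubstituted tail gave a 4.4-fold higher number from compound 1 to compound 3 (0.65 log units; beyond the scatter). The flat step seen with the fluoro group therefore does not extend to every halogen substitution on this ring, and compound 3 is the weakest of the three, with both of its steps beyond the scatter. Nothing measured here explains this loss of activity.

The compounds shown do not separate the identity of the halogen from its place on the ring, which a 2-chlorophenyl or 4-fluorophenyl tail would do. They also leave open how a methoxy group or an amine on that ring would read in this assay.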